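The compounds below may be only part of what the source reports. "The series", "measured", "known", "first", "only" and "open" are said of these compounds alone.

Measured compounds:
Compound 1 `CCNC(=O)C1=Cc2ccc(OC)cc2OC1c1cc(OC)c(OC)c(OC)c1`: in a functional assay for inhibition of nuclear factor NF-kappa-B complex (Homo sapiens) (a higher number here means a weaker inhibitor, a lower number a stronger inhibitor), compound 1 gives only a limit, > 50000 nM.
Compound 2 `CCCCNC(=O)C1=Cc2ccc(OC)cc2OC1c1cc(OC)c(OC)c(OC)c1`: in this assay compound 2 gives 25500 nM.
Compound 3 `COc1ccc2c(c1)OC(c1cc(OC)c(OC)c(OC)c1)C(C(=O)N(C)C)=C2`: in this assay compound 3 gives only a limit, > 50000 nM.

Compound 3 sits at the limit of > 50000 nM in this assay, at which 2 of the 3 values shown sit; its value is a limit, not a number. Compound 4 `COc1ccc2c(c1)OC(c1cc(OC)c(OC)c(OC)c1)C=C2` differs from compound 3 by hydrogen in place of dimethylcarbamoyl on a double-bonded ring carbon. The measured steps that touch compound 3 are a step that the two limits leave unreadable from compound 1 to compound 3 and an at least 1.9-fold higher number from compound 2 to compound 3 (0.29 log units; that floor lies within the scatter): the first cannot be read, the second shows only its floor, which lies within the scatter. Among the compounds with values here, neither of them removes the dimethylcarbamoyl altogether, and the step to compound 4 has no direct precedent among the measured pairs. Compound 4 is expected to stay at or near the limit. The estimated step is a number no higher from compound 3 to compound 4 (the limit leaves the size open). For compound 4 the estimate is 50000 nM, with a range of 20000 nM to 150000 nM.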

Compound 4, half-maximal inhibitory concentration: 17700 nM
Compound 4: the middle estimate sits 2.8-fold (0.45 log units) above what was measured, and the stated range ends above it.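

In this assay, the carbamoyl group on the double-bonded ring carbon proves dispensable: hydrogen there gives an at least 2.8-fold lower number from compound 3 to compound 4 (0.45 log units; beyond the scatter) and an at least 2.8-fold lower number from compound 1 to compound 4 (0.45 log units; beyond the scatter). Both steps are floors, each starting from a limit: the limit of > 50000 nM in this assay, at which 2 of the 4 values shown sit. Set against the butylcarbamoyl group, hydrogen gives a 1.4-fold lower number from compound 2 to compound 4 (0.16 log units; within the scatter), so the two compounds cannot be told apart here.

Going by these compounds, whether any group on this carbon improves on hydrogen stays open; a carboxylic acid, a nitrile or an amide with a longer chain than butyl would test this. On these data alone, the true sizes of the two floor steps also remain unknown.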